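Demethylation of a piperazine on the shared core

The source may hold more compounds than are shown below. What is called first, only, known or untested is meant among the compounds shown, and "the series" means these compounds.

Compound 1 `O=C1CN(C2CCCC2)c2nc(Nc3ccc(N4CCCCC4)cc3)ncc2N1` — 4440 nM
Compound 2 `CN1CCN(c2ccc(Nc3ncc4c(n3)N(C3CCCC3)CC(=O)N4)nc2)CC1` — > 30000 nM

Of the compounds shown here, two on the shared core have been tested in a functional assay on HCT-116 cells (Homo sapiens) for inhibition, read by MTT assay, with a stated time of 48 h; a lower number here means a stronger inhibitor, a higher number a weaker inhibitor. Compound 1 gives 4440 nM in this assay. For compound 2 only a limit is known in this assay, > 30000 nM (the limit of > 30000 nM in this assay, at which 1 of the 2 values shown sits), so no number stands for it. Compound 3 `O=C1CN(C2CCCC2)c2nc(Nc3ccc(N4CCNCC4)cn3)ncc2N1` differs from compound 2 by hydrogen in place of methyl on an amine nitrogen in a ring. For the measured compounds named here, no measured pair covers this change, so its size cannot be read from the data. The step is expected to be small, within the usual scatter, in either direction: a number no higher from compound 2 to compound 3 (the limit leaves the size open). Compound 3 is therefore estimated at 30000 nM in this assay, with an expected range from 8000 nM to 100000 nM, and it is expected that this assay may again report only a limit for compound 3.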

Compound 3, half-maximal inhibitory concentration: > 30000 nM
Compound 3: a limit, no number (the forecaster's own chance of this, stated with the estimate: 65%); the middle value lies on the limit itself.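

In this assay compound 3 gives > 30000 nM, a limit and not a number. Compound 2 also stands at a limit, so no step can be read between compound 2 and compound 3. The compounds shown leave open what size the change from 4-methylpiperazin-1-yl to piperazin-1-yl has in this assay.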